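The compounds below may be only part of what the source reports. "The series", "measured", "known", "first", "only" and "open" are said of these compounds alone.

Compound 2, `O=C(O)CN1Cc2ccc(NC(=O)c3ccc4c(c3)CNCC4)cc2C1=O`, is one of three compounds examined in a functional assay on a cell-free system (Platelet, plasma, Homo sapiens) for inhibition (on this read-out lower numbers stand for stronger inhibition and higher numbers for weaker inhibition), where compound 2 gives 120000 nM. Compound 1, `O=C(O)CCN1Cc2ccc(NC(=O)CCCC3CCNCC3)cc2C1=O`, gives 5900 nM in this assay, and compound 3, `O=C(O)CN1Cc2ccc(NC(=O)c3ccc(C4CCNCC4)cc3)cc2C1=O`, gives 24000 nM in this assay. Compound 2 therefore has the highest number of the three, and its separation from both compound 3 and compound 1 lies beyond the scatter of repeated measurements, so compound 2 is the weakest inhibitor among the measured compounds.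

Compound 4, `O=C(O)CCN1Cc2ccc(NC(=O)c3ccc4c(c3)CNCC4)cc2C1=O`, has not yet been measured in this assay. It differs from compound 2 in one place: carboxymethyl in place of carboxy on a saturated chain carbon bound to an amide-type nitrogen in a ring. The shared core and the amide portion remain unchanged; only the acid-bearing side chain on the ring nitrogen is lengthened.

For the measured compounds named here, no measured pair among the three compounds shows this exact change on its own, so no direct step is available. Compound 1, which carries the longer acid-bearing chain, gives 5900 nM, but its amide portion also differs from that of compound 2, so that comparison is confounded. The estimate for compound 4 is 25000 nM, with a range from 5000 nM to 120000 nM. This estimate means a step of a 4.8-fold lower number from compound 2 to compound 4 (0.68 log units; beyond the scatter), expected to lie beyond the scatter in the direction of stronger inhibition, though with wide uncertainty.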

Compound 4, half-maximal inhibitory concentration: 1100 nM
Compound 4: the middle estimate sits 23-fold (1.36 log units) above what was measured; the measured number lies below the stated range.
By their numbers in this assay, from the lowest: compound 4; then compound 1; then compound 3; then compound 2.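

In this assay, replacing carboxy with carboxymethyl on a saturated chain carbon bound to an amide-type nitrogen in a ring gives a 110-fold lower number from compound 2 to compound 4 (2.04 log units; beyond the scatter). This is the first step among the compounds shown that changes this position alone: the shared core and the amide portion stay the same, so the large move towards stronger inhibition belongs to the change from carboxymethyl to 2-carboxyethyl on the ring nitrogen, and compound 4 now has the lowest number of the four compounds. Nothing available here accounts for the size of this step.

The compounds shown leave open whether a still longer chain ending in a carboxylic acid would lower the number further or raise it again, and whether another acid group, such as a tetrazole, could stand in for the carboxylic acid at the end of the 2-carboxyethyl chain. They also leave open whether the same lengthening would bring a step of similar size with the amide portion of compound 3, since this change is seen with only one amide portion.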